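This account rests on a few compounds, and the source may have more. Where it says the series, first, only, none or still open, it means among the compounds named here.

In a functional assay on aorta (Rattus norvegicus, strain Wistar) for inhibition (a lower number here means that less compound is needed, a higher number that more compound is needed for the effect), compound 1 `Cn1c(=O)c2c(Cl)cccc2c(=O)n1CCN=[N+]=[N-]` gives 13100 nM, and compound 2 `Cn1c(=O)c2c(Cl)cccc2c(=O)n1CCCN=[N+]=[N-]` gives 11700 nM. For the measured compounds named here, the one change between them, (azidomethyl in place of azido on a saturated chain carbon, two bonds along the chain from an aromatic nitrogen), made a 1.1-fold lower number from compound 1 to compound 2 (0.05 log units; within the scatter). Compound 3 `Cn1c(=O)c2cccc(Cl)c2c(=O)n1CCN=[N+]=[N-]` has the same atoms as compound 1 joined differently; the difference between the two cores is not broken down here. In this assay compound 3 gives 13200 nM, which stands within the scatter of both compound 1 and compound 2. Compound 4 `Cn1c(=O)c2cccc(Cl)c2c(=O)n1CCCN=[N+]=[N-]` has not yet been measured. It differs from compound 3 by azidomethyl in place of azido on a saturated chain carbon, two bonds along the chain from an aromatic nitrogen, the same change as between compound 1 and compound 2, at the same place. Because the earlier step of a 1.1-fold lower number from compound 1 to compound 2 (0.05 log units; within the scatter) stayed within the scatter, the expected step here is a 1.1-fold lower number from compound 3 to compound 4 (0.05 log units; within the scatter), also within the scatter. Compound 4 is therefore estimated at 11800 nM, expected to fall between 7000 nM and 20000 nM.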

Compound 4, half-maximal effective concentration: 7440 nM
Compound 4: the middle estimate sits 1.6-fold (0.20 log units) above what was measured; measured number inside the range.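

In this assay, azidomethyl in place of azido gives a 1.8-fold lower number from compound 3 to compound 4 (0.25 log units; within the scatter), and this step can be set beside the same change on the other core: the same change on two cores in this assay, a 1.1-fold lower number (0.05 log units; within the scatter) from compound 1 to compound 2 and a 1.8-fold lower number (0.25 log units; within the scatter) from compound 3 to compound 4, 1.6-fold (0.20 log units) apart, within the scatter of two such steps. So, across these four compounds, the change behaves alike on both cores, with neither step nor the gap between them exceeding the usual scatter. This does not show that the change has a real effect in this assay, and two cores cannot show that it would carry over to a third.

The compounds shown leave open whether a longer chain, such as 4-azidobutyl, would give a step beyond the scatter. They also leave open what an amine in place of azido would do.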